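The compounds below may be only part of what the source reports. "The series", "measured", "known", "first", "only" and "open" are said of these compounds alone.

Working notes on the series in a functional assay on DU-145 cells (Homo sapiens) for inhibition, read by trypan blue exclusion, with a stated time of 96 h; a higher number here means a weaker inhibitor of growth, a lower number a stronger inhibitor of growth.

Compound 1 `COc1ccccc1/C=C(\C(=O)c1ccc(Br)cc1)S(=O)(=O)c1ccc(C)cc1` gives 1000 nM in this assay. Compound 2 `COc1ccc(/C=C(\C(=O)c2ccc(Br)cc2)S(=O)(=O)c2ccc(C)cc2)cc1` gives 1000 nM in this assay. For the measured compounds named here, the only change between these two is 4-methoxyphenyl in place of 2-methoxyphenyl on a double-bonded chain carbon bound to a double-bonded chain carbon and it produced no change at the digits printed from compound 1 to compound 2 (within the scatter), a step that stays within the scatter of repeated measurement.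

Compound 3 `COc1ccccc1/C=C(/Sc1ccc(C)cc1)C(=O)c1ccc(Cl)cc1` gives 25000 nM in this assay, the highest of the three numbers and beyond the scatter from both other compounds. The difference between the core of compound 3 and the core of compound 1 is not broken down here.

Compound 4 `COc1ccc(/C=C(/Sc2ccc(C)cc2)C(=O)c2ccc(Cl)cc2)cc1` has not yet been measured in this assay. It is related to compound 3 by 4-methoxyphenyl in place of 2-methoxyphenyl on a double-bonded chain carbon bound to a double-bonded chain carbon, the same change that turns compound 1 into compound 2, made at the same place. Because no change at the digits printed from compound 1 to compound 2 (within the scatter) lay within the scatter, the step of no change at the digits printed from compound 3 to compound 4 (within the scatter) from compound 3 is expected to be of the same small size. Compound 4 is therefore expected to give about 25000 nM in this assay. Compound 4 is estimated to fall between 10000 nM and 60000 nM.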

Compound 4, concentration for 50% growth inhibition: 1000 nM
The estimate for compound 4 lay 25-fold (1.40 log units) above the measured number; measured number below the stated range.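

In this assay, 4-methoxyphenyl in place of 2-methoxyphenyl on a double-bonded chain carbon bound to a double-bonded chain carbon gives a 25-fold lower number from compound 3 to compound 4 (1.40 log units; beyond the scatter), a large step, whereas the same change gave no change at the digits printed from compound 1 to compound 2 (within the scatter). The two steps therefore do not match, and the result of this change did not carry from the core of compound 1 to the core of compound 3: the same change on two cores in this assay, no change at the digits printed (within the scatter) from compound 1 to compound 2 and a 25-fold lower number (1.40 log units; beyond the scatter) from compound 3 to compound 4, 25-fold (1.40 log units) apart, beyond the scatter of two such steps. This shows that, in these two pairs, the size of the step depends on the core, but it does not show which part of the core is responsible, and two pairs establish no rule for the wider series.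

As far as these compounds go, the core of compound 1 and the core of compound 3 differ in more than one place, so it remains open which of those differences separates the two outcomes. Also open, from the compounds shown here alone, is how a phenyl ring carrying an amine or a carboxylic acid in place of the methoxy would behave on either core.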